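This account rests on a few compounds, and the source may have more. Where it says the series, first, only, none or still open, it means among the compounds named here.

Measured so far in an assay on isolated protein for inhibition of Amine oxidase [flavin-containing] A (Homo sapiens); a lower number here means a stronger inhibitor, a higher number a weaker inhibitor:

compound 1, `CN(C)c1ccc(/C=C/C(=O)c2ccc(N(C)C)cc2O)cc1`, 47900 nM
compound 2, `CCN(CCCCOc1ccc(/C=C/C(=O)c2ccc(N(C)C)cc2O)cc1)Cc1ccccc1OC`, 9200 nM
compound 3, `COc1ccc(/C=C/C(=O)c2ccc(N(C)C)cc2O)cc1`, 42500 nM

Compound 2 gives the lowest number of the three in this assay; its gap to compound 3 and its gap to compound 1 both lie beyond the scatter, with compound 3 the nearer of the two and compound 1 the further. Compound 4, `CCN(CCCCOc1ccc(/C=C/C(=O)c2ccc(N(C)C)cc2O)cc1)Cc1ccccc1N(C)C`, is not yet measured. It differs from compound 2 in one place: dimethylamino in place of methoxy on an aromatic carbon.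

Among the compounds with values here, the only measured step that bears on this swap is the one from compound 1 to compound 3, which exchanges the same two groups in the opposite direction at another part of the shared core: a 1.1-fold lower number from compound 1 to compound 3 (0.05 log units; within the scatter). That step is within the scatter, so the exchange of methoxy for dimethylamino, at least where it was tried, left the number essentially unchanged. Within the data shown here, the step from compound 2 to compound 4 is made at a different place, next to the benzyl attachment of a side chain that compound 1 and compound 3 do not carry, so the one precedent is an imperfect guide; no measured pair speaks to that place directly.

On this basis no step beyond the scatter is expected in this assay, in either direction, and the estimated step from compound 2 to compound 4 is a 1.0-fold lower number from compound 2 to compound 4 (0.01 log units; within the scatter). Compound 4 is therefore estimated at 9000 nM, with a range of 3000 nM to 27000 nM.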

Compound 4, half-maximal inhibitory concentration: 12300 nM
Estimate against measurement, compound 4: 1.4-fold (0.14 log units) below, within the range that was stated.
By their numbers in this assay, from the lowest: compounds 2 and 4 (each within the scatter of the next); then compounds 3 and 1 (each within the scatter of the next).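

In this assay, the change from 2-methoxybenzyl to 2-(dimethylamino)benzyl gives a 1.3-fold higher number from compound 2 to compound 4 (0.13 log units; within the scatter), so at this place, ortho to a large group, the two groups cannot be told apart by this read-out. Within the data shown here, until now, the exchange of these two groups had been seen only on a core without the side chain, and it now reads the same on two cores: the same change on two cores in this assay, a 1.1-fold lower number (0.05 log units; within the scatter) from compound 1 to compound 3 and a 1.3-fold lower number (0.13 log units; within the scatter) from compound 4 to compound 2, 1.2-fold (0.07 log units) apart, within the scatter of two such steps. For the compounds shown, the exchange of methoxy and dimethylamino therefore gives no step beyond the scatter in this assay, whether or not the side chain is present, although the two exchanges sit at different places.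

Going by these compounds, what a group of a different kind would do on this aromatic carbon stays open: a carboxylic acid or a primary amine could still give a step beyond the scatter, which two neutral groups with one acceptor each cannot predict. Also open is how much the side chain itself contributes at each of its parts, since no pair shown isolates the effect of a shorter or longer chain, or of a different amine substituent in place of the ethyl group.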